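Cytotoxicity notes on a thiazolidinone-piperidine series

The source may report more compounds than this note shows. Statements on the series, on what has been measured and on what is new or still open speak of the compounds shown alone.

Measured compounds:
compound 1 `O=C1CSC(c2cccc(Cl)c2)N1CCN1CCCCC1` — 20%
compound 2 `COc1ccccc1C1SCC(=O)N1CCN1CCCCC1` — 17%
compound 3 `O=C1CSC(c2ccccc2[N+](=O)[O-])N1CCN1CCCCC1` — 24%

In an ADME assay on Vero cells (Chlorocebus sabaeus) for cytotoxicity, read by neutral red uptake, tested at 1575 ug/mL (on this read-out lower numbers stand for a stronger effect and higher numbers for a weaker effect at the one concentration tested), compound 1 gives 20%, the second highest of the three numbers. Its nearest neighbour is compound 2, whose value of 17% lies within the scatter of it, and compound 3 at 24% is likewise within the scatter; all three compounds sit close together on this read-out.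

Compound 4 `Cc1ccc(C2SCC(=O)N2CCN2CCCCC2)cc1` is not yet measured. Against compound 1 it differs in one place: 4-methylphenyl in place of 3-chlorophenyl on a saturated ring carbon. Among the compounds with values here, the only measured step that touches the aromatic substituent is a number 7 percentage points higher from compound 2 to compound 3 (within the scatter), and it stayed within the scatter. Within the data shown here, every other gap among the three compounds is also within the scatter, so nothing so far suggests that swapping one aromatic group for another moves this assay much.

The expectation for compound 4 is therefore a step of a number 1 percentage points higher from compound 1 to compound 4 (within the scatter), none beyond the scatter. Compound 4 is estimated at 21%, with a range from 10% to 33%.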

Compound 4, a percentage reported as activity, at one concentration (the size of the read-out at that concentration, not a potency): 13%
Beside the measured number, compound 4's estimate is 8 percentage points above it; the measured number falls inside the stated range.
By their numbers in this assay, from the lowest: compounds 4, 2, 1 and 3 (each within the scatter of the next, the first and the last beyond it).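

In this assay, a number 7 percentage points lower from compound 1 to compound 4 (within the scatter) comes with 4-methylphenyl in place of 3-chlorophenyl on this saturated ring carbon. This position therefore tolerates a change in both the kind of substituent on the aromatic ring and its ring position without a step beyond the scatter, which the earlier nitro-for-methoxy step did not test. No measurement bears on why the number stays within the scatter, and this single step gives no trend across substituents.

As far as these compounds go, it remains open whether a carboxylic acid or a primary amine on the phenyl ring would stay within the scatter of compound 1. Also open, from the compounds shown here alone, is what a pyridine in place of the phenyl ring, or a morpholine at the far end of the shared core, would do on this read-out.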